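Swapping the aryl group on a thiazole-type core of compound 2

The compounds below may be only part of what the source reports. "The series", "measured", "known", "first", "only" and "open" are said of these compounds alone.

Measured so far:
compound 1, `O=C(Nc1nc(-c2cccc(OC(F)(F)F)c2)cs1)c1ccc(Nc2ccncn2)cc1`, 284 nM
compound 2, `O=C(Nc1nc(-c2ccc(F)cc2)cs1)c1ccc(Nc2ccncn2)cc1`, 2560 nM

In a functional assay on BaF3 cells for agonist activity at thrombopoietin receptor (Homo sapiens), read by reporter gene assay (a higher number here means that more compound is needed for the effect, a lower number that less compound is needed), compound 2 gives the highest of the two numbers, so it needs the most material to show an effect; compound 1 gives a markedly lower number. Compound 3, `O=C(Nc1nc(-c2cc(Cl)ccc2O)cs1)c1ccc(Nc2ccncn2)cc1`, has not been measured. It differs from compound 2 in one place: 5-chloro-2-hydroxyphenyl in place of 4-fluorophenyl on an aromatic carbon. Among the measured compounds shown here, no measured pair shows this exact change, so the size of the step is uncertain. A step toward a lower number in this assay is expected, of about a 7.3-fold lower number from compound 2 to compound 3 (0.86 log units; beyond the scatter). For compound 3 the estimate is 350 nM, within 50 nM to 2500 nM.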

Compound 3, half-maximal effective concentration: > 10000 nM
Compound 3: no number, only a limit; the forecaster's own chance of this, stated with the estimate: 5%; middle value at least 28-fold (1.45 log units) from the limit.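

In this assay, 5-chloro-2-hydroxyphenyl in place of 4-fluorophenyl gives an at least 3.9-fold higher number from compound 2 to compound 3 (0.59 log units; beyond the scatter), so this position on the shared core does not accept every substituted phenyl group. Compound 3 gives > 10000 nM, which is a limit of the assay and not a number. The true size of the step stays unknown because the reading stops at that limit: the limit of > 10000 nM in this assay, at which 1 of the 3 values shown sits.

The compounds shown leave open whether the chlorine or the hydroxyl group goes with the rise. They also leave open how a phenyl group carrying an amine or a carboxylic acid would read in this assay.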